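The compounds below may be only part of what the source reports. "The series", "measured", "known", "first", "only" and "open" are said of these compounds alone.

Measured in an ADME assay on cells (Macrophage, Mus musculus) for cytotoxicity, read by resazurin assay, with a stated time of 3 days; on this read-out higher numbers stand for weaker inhibition and lower numbers for stronger inhibition:
- Compound 1 `O=C(Nc1ccc(C(F)(F)F)cc1)c1cc(Cl)ccc1O`: 2800 nM
- Compound 2 `O=C(Nc1ccc(F)cc1)c1cc(Cl)ccc1O`: 17000 nM
- Compound 3 `NC(=O)c1ccc(NC(=O)c2cc(Cl)ccc2O)cc1`: > 60000 nM

Compound 3 reports only a limit of the assay, not a number, as the limit of > 60000 nM in this assay, at which 1 of the 3 values shown sits, notes. Compound 1 has the lower of the two true numbers, and its nearest neighbour is compound 2: a 6.1-fold higher number from compound 1 to compound 2 (0.78 log units; beyond the scatter).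

Compound 4 `O=C(Nc1ccc(C(F)(F)F)cc1)c1cc(F)ccc1O` is the next to consider. It has fluoro in place of chloro on an aromatic carbon, para to a hydroxy group: fluoro in place of chloro on an aromatic carbon.

Among the measured compounds shown here, no measured step touches the chloro, so the evidence is indirect. All three steps change the group that is trifluoromethyl in compound 1: a 6.1-fold higher number from compound 1 to compound 2 (0.78 log units; beyond the scatter), an at least 21-fold higher number from compound 1 to compound 3 (1.33 log units; beyond the scatter) and an at least 3.5-fold higher number from compound 2 to compound 3 (0.54 log units; beyond the scatter). Compound 4 keeps that trifluoromethyl, so none of these larger steps is repeated. In this assay, a small change is therefore expected, about the size of the scatter and, if anything, toward a higher number: a 1.8-fold higher number from compound 1 to compound 4 (0.25 log units; within the scatter).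

For compound 4 the estimated value is 5000 nM, with an expected range of 2000 nM to 14000 nM.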

Compound 4, half-maximal inhibitory concentration: 5400 nM
Beside the measured number, compound 4's estimate is 1.1-fold (0.03 log units) below it; measured number inside the range.
By their numbers in this assay, from the lowest: compounds 1 and 4 (each within the scatter of the next); then compound 2. At a limit, above all of these: compound 3.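

Compound 1, compound 2 and compound 3 all carry chloro at the position para to a hydroxy group, so they could say nothing about it; compound 4 gives the first reading there. In this assay, fluoro in place of chloro gives a 1.9-fold higher number from compound 1 to compound 4 (0.29 log units; within the scatter), so this swap leaves the two compounds indistinguishable, whereas changes at the trifluoromethyl group, such as a 6.1-fold higher number from compound 1 to compound 2 (0.78 log units; beyond the scatter), lie beyond the scatter. No measurement shown here bears on what lies behind this result.

The compounds shown hold only chloro and fluoro at this position, so the effect of an amine, a carboxylic acid or a longer chain there remains open. Among the compounds shown here, the swap is also seen only with trifluoromethyl in place, so whether it would hold alongside fluoro or carbamoyl is unknown.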